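The source may hold more compounds than are shown below. What is called first, only, known or untested is meant among the compounds shown, and "the series" means these compounds.

Working notes on the series. In an ADME assay on Vero 76 cells (Chlorocebus sabaeus) for cytotoxicity, read by neutral red uptake (a lower number here means that less compound is tolerated, a higher number that more compound is tolerated), compound 1 `CC(C)[C@@H](Nc1nc(Cl)nc2c1ncn2[C@H]1[C@H](O)[C@H](O)[C@]2(CF)C[C@H]12)C1CC1` gives 33000 nM, the lowest of the two numbers shown. Compound 3 `OC[C@@]12C[C@@H]1[C@@H](n1ccc3c(NC(C4CCC4)C4CCC4)nc(Cl)nc31)[C@H](O)[C@@H]2O` gives 86000 nM in this assay, and the gap between compound 3 and compound 1 lies beyond the scatter. For compound 2 `CC(C)(C)[C@H](Nc1nc(Cl)nc2c1ncn2[C@H]1[C@H](O)[C@H](O)[C@]2(CO)C[C@H]12)C1CC1` this assay returns only a limit, > 100000 nM. That limit is the one described by the limit of > 100000 nM in this assay, at which 1 of the 3 values shown sits. The unmeasured compound 4 `CC(C)[C@@H](Nc1nc(Cl)nc2c1ncn2[C@H]1[C@H](O)[C@H](O)[C@]2(CN)C[C@H]12)C1CC1` differs from compound 1 by amino in place of fluoro on a saturated chain carbon bound to a saturated ring carbon. Within the data shown here, no measured step follows this change, so the expectation rests on compound 1 alone. The step expected in this assay is a 1.5-fold higher number from compound 1 to compound 4 (0.18 log units; within the scatter). Compound 4 is estimated at 50000 nM, with a range from 20000 nM to 120000 nM.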

Compound 4, half-maximal cytotoxic concentration: 32000 nM
Beside the measured number, compound 4's estimate is 1.6-fold (0.19 log units) above it; the measured number falls inside the stated range.
By their numbers in this assay, from the lowest: compounds 4 and 1 (each within the scatter of the next); then compound 3. At a limit, above all of these: compound 2.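

Amino in place of fluoro on a saturated chain carbon bound to a saturated ring carbon gives a 1.0-fold lower number from compound 1 to compound 4 (0.01 log units; within the scatter) in this assay. This is the only step shown at this place, and it shows that fluoromethyl and aminomethyl there cannot be told apart in this read-out, although the amino group brings a hydrogen-bond donor and acceptor. No measured property shown accounts for this step. As far as these compounds go, what a carboxylic acid or a longer aminoethyl chain at this place would give stays open, as does whether the step holds on other cores.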